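A few compounds are considered here, and "the series" means these few. Any claim that something is new, unique, unknown or untested is made for them only; others in the source may bear on it.

Measured so far:
- compound 1, `O=C(N[C@H]1CN(S(=O)(=O)c2ccccc2)C[C@@H]1C(=O)N[C@H]1CCCNC1)c1cc(-c2ccc(Cl)cc2Cl)on1`: 109%
- compound 2, `O=C(N[C@H]1CN(S(=O)(=O)c2ccccc2)C[C@@H]1C(=O)N1C[C@H]2CCNC[C@H]21)c1cc(-c2ccccc2Cl)on1`: 98%
- compound 3, `CN(C(=O)c1cc(-c2ccccc2Cl)on1)[C@H]1CN(S(=O)(=O)c2ccccc2)C[C@@H]1C(=O)N[C@H]1CCCNC1`: 103%

All three values come from a functional assay on HEK293 cells for agonist activity at growth hormone secretagogue receptor type 1 (Homo sapiens), read by HTRF and inositol phosphate accumulation, with a stated time of 90 min, in the presence of a further agent that is not named here (a higher number here means a larger maximal response, a lower number a smaller maximal response), and all three sit close to the reference response. Compound 2 gives the lowest of the three numbers in this assay. Its nearest neighbour is compound 3, whose value lies within the scatter of that of compound 2; the furthest is compound 1, whose value lies beyond the scatter of that of compound 2. Going by the values given here, no step between two measured compounds that differ in a single place is available, so nothing can be said about how any one change moves the maximal response.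

Compound 4, `CN(C(=O)[C@H]1CN(S(=O)(=O)c2ccccc2)C[C@@H]1NC(=O)c1cc(-c2ccccc2Cl)on1)[C@H]1CCCNC1`, has not been measured. Relative to compound 2 the change is a group of 8 heavy atoms (6 carbon, 2 nitrogen; one six-membered non-aromatic ring with 1 hetero atom) in place of a group of 8 heavy atoms (6 carbon, 2 nitrogen; one four-membered non-aromatic ring with 1 hetero atom, one six-membered non-aromatic ring with 1 hetero atom), on a carbonyl carbon

Since every measured compound in this assay gives a maximal response near the reference, the expectation for compound 4 is no step beyond the scatter, in either direction, with a number 3 percentage points higher from compound 2 to compound 4 (within the scatter) as the estimated move. Compound 4 is thus estimated at 101% in this assay, expected between 88% and 114%.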

Compound 4, largest response reached (Emax), in percent of the reference or control that the assay uses: 88%
The estimate for compound 4 lay 13 percentage points above the measured number; the measured number falls inside the stated range.
By their numbers in this assay, from the lowest: compounds 4, 2, 3 and 1 (each within the scatter of the next, the first and the last beyond it).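

In this assay, the series now has its first comparison at a single place, the carbonyl carbon whose other neighbour is a saturated ring carbon: a number 10 percentage points lower from compound 2 to compound 4 (within the scatter). The group with one four-membered and one six-membered non-aromatic ring and the group with only one six-membered non-aromatic ring therefore cannot be told apart by maximal response, so the four-membered ring is not shown to be needed for this read-out in this pair. No evidence on the origin of the step is available.

Open, on these data alone, is whether an open-chain group at this carbonyl carbon, such as an aminoethyl amide, or a carboxylic acid there would also stay within the scatter. A single pair also leaves open whether the same exchange behaves alike with a different aryl group on the shared core.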